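This account rests on a few compounds, and the source may have more. Where it says the series, first, only, none or still open, it means among the compounds named here.

Two compounds share one core and differ only in the chain that hangs from its oxygen. Compound 1 `COC(=O)CCCCCOc1cc(-c2ccccc2)cc(-c2ccccc2)n1` gives 40 nM in an assay on cell membranes from spleen (Cavia porcellus) for binding affinity to leukotriene B4 receptor 1 (Homo sapiens) (on this read-out lower numbers stand for stronger inhibition and higher numbers for weaker inhibition), and compound 2 `O=C(O)CCCOc1cc(-c2ccccc2)cc(-c2ccccc2)n1` gives 300 nM; of these two numbers, compound 2 holds the higher one, the step being a 7.5-fold higher number from compound 1 to compound 2 (0.88 log units; beyond the scatter). That step exchanges the ester end for an acid and shortens the chain at the same time, so it cannot tell the two changes apart.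

Compound 3 `O=C(O)CCCCOc1cc(-c2ccccc2)cc(-c2ccccc2)n1` keeps the acid of compound 2 and lengthens its chain by one unit: carboxymethyl in place of carboxy on a saturated chain carbon, three bonds along the chain from an oxygen on an aromatic ring. For the measured compounds named here, the only measured step, from compound 1 to compound 2, points to a longer chain being tolerated, but the acid itself went along with it, so the guide is weak. A small move back toward a lower number is expected, roughly a 2.0-fold lower number from compound 2 to compound 3 (0.30 log units; within the scatter). Compound 3 is therefore estimated at 150 nM, within 50 nM to 500 nM.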

Compound 3, half-maximal inhibitory concentration: 50 nM
Estimate against measurement, compound 3: 3.0-fold (0.48 log units) above; the measured number falls inside the stated range.
By their numbers in this assay, from the lowest: compounds 1 and 3 (each within the scatter of the next); then compound 2.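

With the acid end kept, one added chain unit alone gives a 6.0-fold lower number from compound 2 to compound 3 (0.78 log units; beyond the scatter) in this assay, so chain length by itself moves this number, which the earlier step could not show. Compound 3 still differs from compound 1 in both its end group and its chain length, yet a 1.3-fold higher number from compound 1 to compound 3 (0.10 log units; within the scatter) leaves the pair level, so an acid end can sit with a number like that of the methyl ester once the chain is 4-carboxybutyl. Nothing measured here gives a reason for the shift with chain length.

On these data alone, whether a still longer chain ending in a carboxylic acid continues this trend stays open. So does how the methyl ester behaves on the chain of compound 3, the comparison that would isolate the end group from chain length.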